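A few compounds are considered here, and "the series" means these few. Any claim that something is new, unique, unknown or untested is made for them only; others in the source may bear on it.

Working notes on the series, all read in a functional assay (aorta) with Rattus norvegicus as the target; on this read-out higher numbers stand for an effect only at larger amounts of compound and lower numbers for an effect already at smaller amounts. Compound 1 `COc1ccc(-c2nc(CN)sc2-c2ccc(OC)cc2)cc1`, with aminomethyl on the shared core, gives 7.7 uM. Compound 2 `CCN(CC)C(=O)c1nc(-c2ccc(OC)cc2)c(-c2ccc(OC)cc2)s1`, with diethylcarbamoyl in that place, gives 14 uM. That exchange amounts to a 1.8-fold higher number from compound 1 to compound 2 (0.26 log units; within the scatter). Compound 3 `CCOC(=O)/C=C/c1nc(-c2ccc(OC)cc2)c(-c2ccc(OC)cc2)s1`, with 2-(ethoxycarbonyl)ethenyl in the same place, reads > 100 uM, which is a limit of the assay and not a number. Compound 3 therefore stands at the limit of > 100 uM in this assay, at which 1 of the 3 values shown sits. The measured steps to it are an at least 12-fold higher number from compound 1 to compound 3 (1.11 log units; beyond the scatter) and an at least 7.1-fold higher number from compound 2 to compound 3 (0.85 log units; beyond the scatter).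

Compound 4 `COc1ccc(-c2nc(C3=CCN(C)CC3)sc2-c2ccc(OC)cc2)cc1` has not yet been measured. Its change is a group of 7 heavy atoms (6 carbon, 1 nitrogen; one six-membered non-aromatic ring with 1 hetero atom) in place of a group of 7 heavy atoms (5 carbon, 2 oxygen; no ring), on an aromatic carbon: 2-(ethoxycarbonyl)ethenyl leaves, and a six-membered non-aromatic ring with a hetero atom enters.

Both of the steps to compound 3 bear on this change when read in reverse, since each points to a large move towards lower numbers once 2-(ethoxycarbonyl)ethenyl is replaced. Like compound 1 at 7.7 uM and compound 2 at 14 uM, compound 4 carries nitrogen in this place. Within the data shown here, no measured compound carries the entering ring, so the range stays wide. The expected move is large and towards a lower number, an at least 6.6-fold lower number from compound 3 to compound 4 (0.82 log units; beyond the scatter). For compound 4 the estimated value is 15 uM, with an expected range of 4 uM to 60 uM.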

Compound 4, concentration for half-maximal effect: 5.9 uM
Estimate against measurement, compound 4: 2.5-fold (0.41 log units) above, within the range that was stated.
By their numbers in this assay, from the lowest: compounds 4, 1 and 2 (each within the scatter of the next, the first and the last beyond it). At a limit, above all of these: compound 3.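

In this assay, this position on the aromatic carbon next to the ring nitrogen and the ring sulfur also accepts a six-membered non-aromatic ring with a hetero atom, and the step of an at least 16-fold lower number from compound 3 to compound 4 (1.22 log units; beyond the scatter) starts from a limit of the assay, not a number: the limit of > 100 uM in this assay, at which 1 of the 4 values shown sits.

Against the much smaller aminomethyl the ring leaves no difference beyond the scatter, at a 1.3-fold lower number from compound 1 to compound 4 (0.12 log units; within the scatter), whereas against diethylcarbamoyl, which has the same number of heavy atoms, there is a modest step, a 2.4-fold lower number from compound 2 to compound 4 (0.38 log units; beyond the scatter). Across these four compounds, then, heavy-atom count does not sort the results, while the three groups containing nitrogen give measured numbers and only the 2-(ethoxycarbonyl)ethenyl group, which has none, stands at a limit.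

From the compounds shown here alone, it remains open which feature of the entering group matters: the ring nitrogen, its methyl, the ring double bond or the ring itself. A cyclohexenyl group, an open-chain tertiary amine or a carboxylic acid at this position would separate these readings, and nothing here tells how far the pattern extends to other groups.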